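A few compounds are considered here, and "the series" means these few. Any claim that something is new, unique, unknown or untested is made for them only; others in the source may bear on it.

Measured compounds:
compound 1 `O=C(Nc1ccccc1-c1ccccc1)[C@@H]1CCCN1C(=O)CSc1nc2ccccc2[nH]1`: 0.6 nM
compound 2 `Cn1c(SCC(=O)N2CCC[C@H]2C(=O)Nc2ccccc2-c2ccccc2)nc2ccccc21`: 0.2 nM

In an assay on CHO cells for displacement of a labelled ligand from Orexin receptor type 2 (Homo sapiens) (on this read-out lower numbers stand for stronger inhibition and higher numbers for weaker inhibition), compound 2 gives 0.2 nM, the lowest of the two numbers. Its nearest neighbour is compound 1 with 0.6 nM; the step of a 3.0-fold lower number from compound 1 to compound 2 (0.48 log units; beyond the scatter) came from methyl in place of hydrogen on an aromatic nitrogen. Compound 3 `Cn1c(CCC(=O)N2CCC[C@H]2C(=O)Nc2ccccc2-c2ccccc2)nc2ccccc21` differs from compound 2 by (1-methyl-1H-benzimidazol-2-yl)methyl in place of (1-methyl-1H-benzimidazol-2-yl)sulfanyl on a saturated chain carbon bound to a carbonyl carbon. Going by the values given here, no measured step touches a change of this kind, so the expectation rests only on the strong numbers of the shared core. The expected change is a modest rise, a 3.0-fold higher number from compound 2 to compound 3 (0.48 log units; beyond the scatter). Compound 3 is expected to give 0.6 nM, within a range from 0.15 nM to 3 nM.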

Compound 3, inhibition constant in the Orexin receptor type 2 assay: 0.8 nM
Beside the measured number, compound 3's estimate is 1.3-fold (0.12 log units) below it; the measured number falls inside the stated range.
By their numbers in the Orexin receptor type 2 assay, from the lowest: compound 2; then compounds 1 and 3 (each within the scatter of the next).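

Replacing the sulfanyl link with a methyl link on a saturated chain carbon bound to a carbonyl carbon has a real cost in the Orexin receptor type 2 assay, with a 4.0-fold higher number from compound 2 to compound 3 (0.60 log units; beyond the scatter). The same change also has a gain in a physicochemical assay for lipophilicity (a higher number here means a more lipophilic compound, a lower number a more polar compound), where the compound becomes less lipophilic: the measured partition coefficient of compound 2, 3.4, and of compound 3, 2.6, a number 0.80 log units lower (beyond the scatter). In the physicochemical assay compound 2 gives 3.4 and compound 3 gives 2.6. Taken together with the methyl on the aromatic nitrogen, the change leaves a 1.3-fold higher number from compound 1 to compound 3 (0.12 log units; within the scatter) in the Orexin receptor type 2 assay.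

As far as these compounds go, whether an ether oxygen or an amine in this place would hold the binding number of compound 2 stays open. So does the effect of a longer chain.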